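From Phenyl to Benzyl on a Shared Core

The source may report more compounds than this note shows. Statements on the series, on what has been measured and on what is new or still open speak of the compounds shown alone.

Three compounds share one core and differ only in the group on one aromatic carbon. In a functional assay on HeLa cells (Homo sapiens) for inhibition, read by cell counting, with a stated time of 4 days (on this read-out lower numbers stand for stronger inhibition and higher numbers for weaker inhibition), compound 1 `C=C(Br)C(=O)Nc1cccc(-c2cn3nc(-c4ccc(OC)c(OC)c4)sc3n2)c1` gives 610 nM. Compound 2 `C=C(Br)C(=O)Nc1cccc(-c2cn3nc(Cc4ccc(OC)cc4)sc3n2)c1` gives 2300 nM. Compound 3 `C=C(Br)C(=O)Nc1cccc(-c2cn3nc(-c4ccccc4)sc3n2)c1` gives 1400 nM, the second highest of the three numbers. The unmeasured compound 4 `C=C(Br)C(=O)Nc1cccc(-c2cn3nc(Cc4ccccc4)sc3n2)c1` differs from compound 3 by benzyl in place of phenyl on an aromatic carbon. The closest measured step is a 1.6-fold lower number from compound 2 to compound 3 (0.22 log units; within the scatter), whose groups carry an extra methoxy compared with phenyl and benzyl; the step of a 3.8-fold higher number from compound 1 to compound 2 (0.58 log units; beyond the scatter) also brings in a benzyl-type group but changes more at once. From these, compound 4 is expected to move little, a 1.3-fold higher number from compound 3 to compound 4 (0.11 log units; within the scatter), toward a somewhat higher number. Compound 4 is estimated at 1800 nM, with a range from 800 nM to 4000 nM.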

Compound 4, half-maximal inhibitory concentration: 4500 nM
For compound 4 the middle estimate is 2.5-fold (0.40 log units) below the measured one; measured number outside the range, above it.
By their numbers in this assay, from the lowest: compound 1; then compounds 3, 2 and 4 (each within the scatter of the next, the first and the last beyond it).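

With no methoxy on either group, benzyl in place of phenyl gives a 3.2-fold higher number from compound 3 to compound 4 (0.51 log units; beyond the scatter) at this position, so the change now stands clear of the scatter, which the comparison of compound 2 with compound 3 did not show. Hydrogen in place of methoxy on the benzyl group gives a 2.0-fold higher number from compound 2 to compound 4 (0.29 log units; within the scatter) and so shows no clear effect of that methoxy. Against 3,4-dimethoxyphenyl, benzyl gives a 7.4-fold higher number from compound 1 to compound 4 (0.87 log units; beyond the scatter) as the widest step in this set.

On these data alone, whether an amine on the phenyl ring or a longer chain such as phenylethyl would bring the number closer to that of compound 1 stays open. No measurement at hand explains these steps.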